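A few compounds are considered here, and "the series" means these few. Any claim that something is new, unique, unknown or untested is made for them only; others in the source may bear on it.

Measured so far:
compound 1 `CCOC(=O)CCCCCOc1cccc(CN(C(=O)c2ccc(-c3cccc(OCc4ccccc4)c3)cc2)C(C)C)c1` gives > 26000 nM
compound 2 `CCOC(=O)CCCCCOc1cccc(CN(C(=O)c2ccc(-c3cc(OC)cc(OC)c3)cc2)C(C)C)c1` gives > 26000 nM

In an ADME assay on HEK293 cells (Homo sapiens) for cytotoxicity, read by CellTiter-Glo and resazurin assay, with a stated time of 72 h (on this read-out higher numbers stand for an effect only at larger amounts of compound and lower numbers for an effect already at smaller amounts), compound 1 is reported only as a limit, > 26000 nM. In this assay compound 2 is likewise reported only as a limit, > 26000 nM. Compound 2 thus stands at the limit of > 26000 nM in this assay, at which 2 of the 2 values shown sit, with no number to set it apart from compound 1. Compound 3 `CCOC(=O)CCCCCOc1cccc(CN(C(=O)c2ccc(-c3cccc(S(C)(=O)=O)c3)cc2)C(C)C)c1` is not yet measured in this assay; it differs from compound 2 by 3-(methylsulfonyl)phenyl in place of 3,5-dimethoxyphenyl on an aromatic carbon. Going by the values given here, no measured step ties such a change to a shift in this assay, so no step beyond the scatter is expected in either direction. Compound 3 is therefore expected near the limit again, at 30000 nM, between 15000 nM and 60000 nM, which means a step that the limit leaves unreadable from compound 2 to compound 3.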

Compound 3, half-maximal effective concentration: > 26000 nM
Compound 3: no number, only a limit; the forecaster's own chance of this, stated with the estimate: 85%; the middle value is on the limit's open side.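

No step can be read among compound 1, compound 2 and compound 3 in this assay, as each is reported only as a limit: the limit of > 26000 nM in this assay, at which 3 of the 3 values shown sit.

The compounds shown leave open whether these three differ at all, and at what concentration any of them would show an effect.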